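The compounds below may be only part of what the source reports. "The series", "measured", "known", "first", "only" and "open" are said of these compounds alone.

Measured in a functional assay on NCI-H460 cells (Homo sapiens) for cytotoxicity, read by MTT assay, with a stated time of 24 h; on this read-out lower numbers stand for stronger inhibition and higher numbers for weaker inhibition:
- Compound 1 `C=CCn1c(=O)c(C=O)cc2ccccc21`: > 100000 nM
- Compound 2 `C#CCn1c(=O)c(C=O)cc2cc(Cl)ccc21`: > 100000 nM

Compound 1 shows a limit of the assay, not a number. Compound 2 also stands at a limit, > 100000 nM, with no exact value. Compound 3 `C#CCn1c(=O)c(C=O)cc2cc(OC)ccc21` brings one structural change, methoxy in place of chloro on an aromatic carbon. Among the compounds with values here, no measured pair yet shows what such a change does. The expectation therefore rests on (the limit of > 100000 nM in this assay, at which 2 of the 2 values shown sit). The expected step of a number no higher from compound 2 to compound 3 (the limit leaves the size open) is no larger than the usual scatter. Compound 3 is estimated at 100000 nM, with an expected range of 30000 nM to 200000 nM.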

Compound 3, half-maximal inhibitory concentration: > 100000 nM
Compound 3: only a limit was reported (the forecaster's own chance of this, stated with the estimate: 80%); the middle value lies on the limit itself.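

Within the data shown here, compound 2 and compound 3 both stand at a limit in this assay, not at a number, so no step between them can be read. The compounds shown leave open which change to the shared core, if any, would give a measurable value.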